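An open-chain diol in place of the sugar ring

This account rests on a few compounds, and the source may have more. Where it says the series, first, only, none or still open, it means among the compounds named here.

Compound 1 `O=C1c2c[n+]([O-])c3ccccc3c2C(=O)c2c1c1ccccc1n2Cc1cn([C@@H]2C[C@H](O)[C@@H](CO)O2)nn1`: in a functional assay on HCT-116 cells (Homo sapiens) for cytotoxicity, read by MTT assay, with a stated time of 72 h (on this read-out lower numbers stand for stronger inhibition and higher numbers for weaker inhibition), compound 1 gives 50 nM.
Compound 2 `O=C1c2c[n+]([O-])c3ccccc3c2C(=O)c2c1c1ccccc1n2CCN1CCCC1`: in this assay compound 2 gives 270 nM.

Of the two measured compounds, compound 1 has the lower number, and therefore the stronger inhibition. Compound 2 gives a higher number, and the gap between the two lies beyond the usual scatter of repeated measurements. Both share the same core, and they differ only in what hangs from the nitrogen of that core.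

Compound 3 `O=C1c2c[n+]([O-])c3ccccc3c2C(=O)c2c1c1ccccc1n2Cc1cn(C[C@@H](O)CO)nn1` keeps the core of compound 1 and the five-membered aromatic ring with 3 nitrogen that links to it. The change is 2,3-dihydroxypropyl in place of 4-hydroxy-5-(hydroxymethyl)oxolan-2-yl on an aromatic nitrogen. The ring with one hetero atom that carried two hydroxyl groups leaves, and an open chain carrying two hydroxyl groups enters at the same aromatic nitrogen.

Within the data shown here, no pair of measured compounds shows exactly this kind of change, so there is no measured step to lean on. Given that compound 1 gives 50 nM, the expectation is that compound 3 will land fairly close to it, and that a 2.4-fold higher number from compound 1 to compound 3 (0.38 log units; beyond the scatter) is expected to be a modest rise in number, near the edge of the scatter. Compound 3 is estimated at 120 nM, with a range from 50 nM to 300 nM.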

Compound 3, half-maximal inhibitory concentration: 190 nM
Beside the measured number, compound 3's estimate is 1.6-fold (0.20 log units) below it; the measured number falls inside the stated range.
By their numbers in this assay, from the lowest: compound 1; then compounds 3 and 2 (each within the scatter of the next).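

In this assay, opening the ring at this aromatic nitrogen is not a neutral swap: 2,3-dihydroxypropyl in place of 4-hydroxy-5-(hydroxymethyl)oxolan-2-yl gives a 3.8-fold higher number from compound 1 to compound 3 (0.58 log units; beyond the scatter), even though both groups count the same number of hydrogen-bond donors, so keeping two hydroxyl groups is not enough to hold the number of compound 1. The other step, 1-(2,3-dihydroxypropyl)-1H-1,2,3-triazol-4-yl in place of (pyrrolidin-1-yl)methyl, gives a 1.4-fold lower number from compound 2 to compound 3 (0.15 log units; within the scatter), so among these compounds the open-chain diol shows no separable gain over the pyrrolidine side chain, and only the complete ring-bearing group of compound 1 stands apart. Nothing available explains why the ring makes this difference.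

The step from compound 1 to compound 3 changes the ring and the defined stereocentres together, which leaves open which of them accounts for it. Also open, as far as these compounds go, is how a cyclopentane ring carrying the same hydroxyl groups, a longer chain ending in one hydroxyl, an amine or a carboxylic acid would fare on this same aromatic nitrogen.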